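Same Atoms, Joined Differently: A Stability Estimate

A few compounds are considered here, and "the series" means these few. Any claim that something is new, unique, unknown or untested is made for them only; others in the source may bear on it.

- compound 1 `CCc1ccc(-c2cc(NCC3CCN(C)CC3)c3cc(OC)c(OCCCN4CCCC4)cc3n2)o1` gives 59.1%
- compound 2 `COc1cc2c(NC3CC4(CCN(C)CC4)C3)cc(-c3ccc(C)o3)nc2cc1OCCCN1CCCC1` gives 40.6%

In an ADME assay on microsomes from liver (Mus musculus) for metabolic stability, read by LC-MS, with stated times of 10 min and 20 min, tested at 1 uM (on this read-out lower numbers stand for a less stable compound and higher numbers for a more stable compound), compound 2 stands at 40.6%, the lower of the two numbers, and its gap to compound 1 lies beyond the scatter. Compound 3 `COc1cc2c(NC3CCC34CCN(C)CC4)cc(-c3ccc(C)o3)nc2cc1OCCCN1CCCC1` has not yet been measured. It has the same atoms as compound 2, joined differently, on a nitrogen on an aromatic ring: a group of 10 heavy atoms (9 carbon, 1 nitrogen; one four-membered non-aromatic ring of carbon only, one six-membered non-aromatic ring with 1 hetero atom) in place of a group of 10 heavy atoms (9 carbon, 1 nitrogen; one four-membered non-aromatic ring of carbon only, one six-membered non-aromatic ring with 1 hetero atom), on a nitrogen on an aromatic ring. Among the compounds with values here, no measured pair shows a change of this kind. The expected step in this assay is therefore none beyond the scatter, and the estimated step is a number 3.4 percentage points higher from compound 2 to compound 3 (within the scatter). For compound 3 the estimate is 44%, with an expected range from 27% to 61%.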

Compound 3, percent of the compound remaining: 53.3%
For compound 3 the middle estimate is 9.3 percentage points below the measured one, within the range that was stated.
By their numbers in this assay, from the lowest: compound 2; then compounds 3 and 1 (each within the scatter of the next).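

With the atoms unchanged and only their joining different, the group on a nitrogen on an aromatic ring still moves the read-out in this assay, giving a number 12.7 percentage points higher from compound 2 to compound 3 (beyond the scatter). The counts of atoms and rings are identical on both sides, so in this one pair they do not settle the number at this position; the way the four-membered and six-membered rings are joined goes with the difference. Nothing available gives a reason for this step.

As far as these compounds go, it remains open whether a similar number would follow with a morpholine or an open-chain dimethylamine at the same place.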